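Acetylation of a Hydroxyl in a Cytotoxicity Series

The source may hold more compounds than are shown below. What is called first, only, known or untested is meant among the compounds shown, and "the series" means these compounds.

Three compounds have been measured in a functional assay on Lu1 cells (Homo sapiens) for cytotoxicity, read by sulforhodamine B assay; on this read-out lower numbers stand for an effect already at smaller amounts and higher numbers for an effect only at larger amounts of compound:

Compound 1 `C=C1CC[C@@H]2[C@](C)(CO[Si](c3ccccc3)(c3ccccc3)C(C)(C)C)[C@H](OC(C)=O)CC[C@@]2(C)[C@@H]1C/C=C1/C(=O)OC[C@H]1O`: 10.9 uM
Compound 2 `C=C1CC[C@@H]2[C@](C)(CO[Si](c3ccccc3)(c3ccccc3)C(C)(C)C)[C@H](O)CC[C@@]2(C)[C@@H]1C/C=C1/C(=O)OC[C@H]1O`: 11.5 uM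
Compound 3 `C=C1CC[C@@H]2[C@](C)(COC(C)=O)[C@H](O)CC[C@@]2(C)[C@@H]1C/C=C1/C(=O)OC[C@H]1O`: 14 uM

Compound 1 and compound 2 differ only by acetyl in place of hydrogen on an oxygen on a saturated carbon. That change gave a 1.1-fold lower number from compound 2 to compound 1 (0.02 log units; within the scatter), so the two values cannot be told apart. Compound 3 and compound 2 carry different cores; the difference between the two cores is not broken down here. Compound 4 `C=C1CC[C@@H]2[C@](C)(COC(C)=O)[C@H](O)CC[C@@]2(C)[C@@H]1C/C=C1/C(=O)OC[C@H]1OC(C)=O` has not yet been measured. It differs from compound 3 by acetyl in place of hydrogen on an oxygen on a saturated carbon, which is the same change as that made from compound 2 to compound 1. Resting only on that earlier step, a 1.1-fold lower number from compound 2 to compound 1 (0.02 log units; within the scatter), an equally small step is expected in this assay, namely a 1.1-fold lower number from compound 3 to compound 4 (0.03 log units; within the scatter). Compound 4 is therefore estimated to give 13 uM, with a likely range from 7 uM to 25 uM.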

Compound 4, concentration for half-maximal effect: 19.8 uM
The estimate for compound 4 lay 1.5-fold (0.18 log units) below the measured number; the range from low to high includes it.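

Replacing hydrogen with acetyl, which turns a hydroxy group into an acetoxy group, gave a 1.4-fold higher number from compound 3 to compound 4 (0.15 log units; within the scatter) in this assay. Set beside the earlier step, this result gives no sign that the change behaves differently on the two cores: the same change on two cores in this assay, a 1.1-fold lower number (0.02 log units; within the scatter) from compound 2 to compound 1 and a 1.4-fold higher number (0.15 log units; within the scatter) from compound 3 to compound 4, 1.5-fold (0.17 log units) apart, within the scatter of two such steps. Among these compounds, this shows only that the change had no effect that can be told from scatter in these two pairs; it does not show that the change would stay as small on any other core, and neither step fixes a direction for it.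

The compounds shown leave open what a longer chain, such as butanoyl, would do in place of acetyl. They also leave open the effect of an amine in place of the hydroxy group.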